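Series notes: a second fluoro analogue

A few compounds are considered here, and "the series" means these few. Any claim that something is new, unique, unknown or untested is made for them only; others in the source may bear on it.

In a toxicity assay on cells (Macrophage, Mus musculus, strain BALB/c) for cytotoxicity, read by MTT assay (a lower number here means a stronger inhibitor, a higher number a weaker inhibitor), compound 3 `COc1cc(O)cc(O)c1C(=O)/C=C/c1ccc(O)cc1` gives 21700 nM, which puts it second highest of the three numbers, with compound 1 `COc1cc(O)cc(O)c1C(=O)/C=C/c1ccc(Cl)cc1` nearest at 19000 nM and compound 2 `COc1cc(O)cc(O)c1C(=O)/C=C/c1ccc(F)cc1` furthest at 28800 nM; all three lie within the scatter of one another. The measured steps are small throughout: a 1.5-fold higher number from compound 1 to compound 2 (0.18 log units; within the scatter), a 1.1-fold higher number from compound 1 to compound 3 (0.06 log units; within the scatter) and a 1.3-fold lower number from compound 2 to compound 3 (0.12 log units; within the scatter). Compound 4 `COc1cc(O)cc(O)c1C(=O)/C=C/c1ccccc1F` differs from compound 3 as follows: 2-fluorophenyl in place of 4-hydroxyphenyl on a double-bonded chain carbon bound to a double-bonded chain carbon. The step that bears on it most directly is a 1.3-fold lower number from compound 2 to compound 3 (0.12 log units; within the scatter), in which hydroxy replaced fluoro on an aromatic carbon and the number stayed within the scatter; the exchange of chloro for fluoro, a 1.5-fold higher number from compound 1 to compound 2 (0.18 log units; within the scatter), was likewise within the scatter. The series holds no comparison between the two fluoro-bearing rings, so no step beyond the scatter is expected in this assay, that is a 1.1-fold higher number from compound 3 to compound 4 (0.04 log units; within the scatter). Compound 4 is therefore estimated at 24000 nM, with a range from 12000 nM to 48000 nM.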

Compound 4, half-maximal inhibitory concentration: 16000 nM
Estimate against measurement, compound 4: 1.5-fold (0.18 log units) above; low and high end bracket the measured number.
By their numbers in this assay, from the lowest: compounds 4, 1, 3 and 2 (each within the scatter of the next).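

The exchange of 4-fluorophenyl for 2-fluorophenyl on a double-bonded chain carbon bound to a double-bonded chain carbon gives the series its first comparison of two fluoro-bearing rings, and a 1.8-fold lower number from compound 2 to compound 4 (0.26 log units; within the scatter) stays within the scatter in this assay. The exchanges of 4-hydroxyphenyl and 4-chlorophenyl for 2-fluorophenyl give a 1.4-fold lower number from compound 3 to compound 4 (0.13 log units; within the scatter) and a 1.2-fold lower number from compound 1 to compound 4 (0.07 log units; within the scatter), both also within the scatter, so the four rings at this place cannot be told apart in this assay. No measurement shown gives a reason for this result.

Whether any group at this place reaches beyond the scatter remains open, since the compounds shown carry only fluoro, chloro and hydroxy on the ring. A ring bearing an amine or a carboxylic acid, or a longer chain in place of the ring, could test this.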